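The source may report more compounds than this note shows. Statements on the series, on what has been measured and on what is new or still open speak of the compounds shown alone.

Measured in an ADME assay on HepG2 2.2.15 cells (Homo sapiens) for cytotoxicity; a higher number here means that more compound is tolerated, a lower number that less compound is tolerated:
Compound 1, `CCC(C)[C@H](N)C(=O)OC1CCN(S(=O)(=O)c2cc(C(=O)Nc3cc(F)c(F)c(F)c3)ccc2F)CC1`, sits at the assay limit, > 10000 nM.
Compound 2, `CC(C)C[C@H](N)C(=O)OC1CCN(S(=O)(=O)c2cc(C(=O)Nc3cc(F)c(F)c(F)c3)ccc2F)CC1`, gives 5770 nM.
Compound 3, `CC(C)(C)[C@H](N)C(=O)OC1CCN(S(=O)(=O)c2cc(C(=O)Nc3cc(F)c(F)c(F)c3)ccc2F)CC1`, sits at the assay limit, > 10000 nM.

Compound 3 thus yields only a limit and no number; the same holds for (the limit of > 10000 nM in this assay, at which 2 of the 3 values shown sit). Compound 4, `NCC(=O)OC1CCN(S(=O)(=O)c2cc(C(=O)Nc3cc(F)c(F)c(F)c3)ccc2F)CC1`, differs from compound 3 by hydrogen in place of tert-butyl on a saturated chain carbon bound to an amine nitrogen and a carbonyl carbon. The steps measured at this carbon are an at least 1.7-fold lower number from compound 1 to compound 2 (0.23 log units; that floor lies within the scatter), an at least 1.7-fold higher number from compound 2 to compound 3 (0.23 log units; that floor lies within the scatter) and a step that the two limits leave unreadable from compound 1 to compound 3: none reads as beyond the scatter, and two of them rest on a limit. Within the data shown here, compound 4 alters the same place once more, and no measured step tests this kind of change, so no shift beyond the scatter is expected in this assay. Compound 4 is therefore estimated at 10000 nM (4000 nM to 30000 nM). The expected step is a number no higher from compound 3 to compound 4 (the limit leaves the size open), most likely reported again only as a limit.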

Compound 4, half-maximal cytotoxic concentration: > 10000 nM
Compound 4: a limit, no number; the forecaster's own chance of this, stated with the estimate: 60%; the middle value lies on the limit itself.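

In this assay compound 4 gives > 10000 nM, a limit of the assay and not a number. Hydrogen in place of isobutyl gives an at least 1.7-fold higher number from compound 2 to compound 4 (0.23 log units; that floor lies within the scatter), so even with the side chain gone from this carbon, no step reads as beyond the scatter. The steps to compound 4 from compound 1 and compound 3 cannot be read because both ends of each rest on a limit: the limit of > 10000 nM in this assay, at which 3 of the 4 values shown sit.

From the compounds shown here alone, what a longer chain or a carboxylic acid on this carbon would give stays open. Going by these compounds, how far the compounds at the limit lie from one another also stays open.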